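Cyclopropyl to cyclopentyl: from compound 1 to compound 4

This account rests on a few compounds, and the source may have more. Where it says the series, first, only, none or still open, it means among the compounds named here.

In an ADME assay on HEK-293T cells (Homo sapiens) for cytotoxicity, read by resazurin assay, with a stated time of 16 h (a lower number here means a stronger inhibitor, a higher number a weaker inhibitor), compound 1 (`OC[C@H]1O[C@@H](n2cnc3c(NC4CC4)nc(NC4CC4)nc32)[C@H](O)[C@@H]1O`) stands at "not determined" (no result reported), so this step starts from no number. Compound 4 (`OC[C@H]1O[C@@H](n2cnc3c(NC4CC4)nc(NC4CCCC4)nc32)[C@H](O)[C@@H]1O`) differs from it by a single change, (cyclopentyl in place of cyclopropyl on a nitrogen on an aromatic ring), which is cyclopentyl in place of cyclopropyl on a nitrogen on an aromatic ring.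

Within the data shown here, two related compounds give the only guidance. Compound 2 (`OC[C@H]1O[C@@H](n2cnc3c(NC4CCCC4)nc(NC4CC4)nc32)[C@H](O)[C@@H]1O`) gives only a limit, > 500000 nM. Compound 3 (`OC[C@H]1O[C@@H](n2cnc3c(NC4CCCC4)nc(NC4CCCCC4)nc32)[C@H](O)[C@@H]1O`) gives an actual number, 228000 nM. Among the measured compounds shown here, the one measured step that bears on the change is an at least 2.1-fold lower number from compound 2 to compound 3 (0.34 log units; beyond the scatter), with cyclohexyl in place of cyclopropyl on a nitrogen on an aromatic ring. This is at least a modest step, and it is a single pair, so it sets no general pattern.

By analogy, a modest step towards a lower number is expected from compound 1 to compound 4 in this assay, though without a starting number its size cannot be checked. Compound 4 carries the same two groups as compound 2, exchanged, so a reading close to the limit, or only a limit, would be no surprise. Compound 4 is expected at about 380000 nM, with an estimated range of 170000 nM to 500000 nM.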

Compound 4, half-maximal inhibitory concentration: > 500000 nM
Compound 4: only a limit was reported (the forecaster's own chance of this, stated with the estimate: 50%); at least 1.3-fold (0.11 log units) between middle value and limit.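

In this assay compound 4 gives > 500000 nM, which is a limit and not a number. No step can be read from compound 1 to compound 4, since neither compound has a number. Left open is whether cyclopentyl in place of cyclopropyl on this nitrogen changes the reading at all.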